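From 3-nitrophenyl to 4-(dimethylamino)phenyl on compound 1

A few compounds are considered here, and "the series" means these few. Any claim that something is new, unique, unknown or untested is made for them only; others in the source may bear on it.

In an ADME assay on Vero cells (Chlorocebus sabaeus) for cytotoxicity, read by MTT assay, with a stated time of 72 h (on this read-out higher numbers stand for weaker inhibition and lower numbers for stronger inhibition), compound 1 `CC(=O)N1N=C(c2ccc(-n3c(C)ccc3C)cc2)OC1c1cccc([N+](=O)[O-])c1` gives 188000 nM. Compound 3 `O=[N+]([O-])c1ccccc1-c1nnc(-c2ccc(-n3cccc3)cc2)o1` gives 266000 nM, and this pair of numbers lies within the usual scatter of repeated measurements, so the two cannot be told apart. For compound 2 `Cc1ccc(C)n1-c1ccc(C(=O)N/N=C/c2ccc(O)cc2)cc1` the entry reads "not determined" (no result reported), which leaves compound 1 with a single measured neighbour.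

Compound 4 `CC(=O)N1N=C(c2ccc(-n3c(C)ccc3C)cc2)OC1c1ccc(N(C)C)cc1` has not yet been measured. It keeps the core of compound 1 and changes one group on a saturated ring carbon, with 4-(dimethylamino)phenyl in place of 3-nitrophenyl (4-(dimethylamino)phenyl in place of 3-nitrophenyl on a saturated ring carbon). Among the compounds with values here, no two measured compounds differ in just one place, so the data do not show directly what such a swap does in this assay. Within the data shown here, with no measured step to suggest otherwise, the expectation is no shift beyond the scatter, an estimated 1.1-fold lower number from compound 1 to compound 4 (0.04 log units; within the scatter). Compound 4 is expected to give about 170000 nM, with an estimated range from 70000 nM to 350000 nM.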

Compound 4, half-maximal inhibitory concentration: 175000 nM
The estimate for compound 4 lay 1.0-fold (0.01 log units) below the measured number; low and high end bracket the measured number.
By their numbers in this assay, from the lowest: compounds 4, 1 and 3 (each within the scatter of the next).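

Within the data shown here, replacing 3-nitrophenyl with 4-(dimethylamino)phenyl on a saturated ring carbon gives the first single-place comparison in this assay, with a 1.1-fold lower number from compound 1 to compound 4 (0.03 log units; within the scatter). This means that, for this one pair, two different groups on the same aromatic ring of carbon leave the read-out within the scatter, so this position can carry either group without a measurable shift. Nothing measured here explains why the two compounds read alike.

This swap alters both the group on the phenyl ring and its place on that ring, so a 4-nitrophenyl or a 3-(dimethylamino)phenyl group would be needed to separate the two changes. Going by these compounds, it also remains open whether the same holds for a group without a phenyl ring, such as a butyl chain, or for a phenyl ring carrying a carboxylic acid.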